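Dithiocarbamate triazole series: the trimethoxyphenyl step

This account rests on a few compounds, and the source may have more. Where it says the series, first, only, none or still open, it means among the compounds named here.

Compound 1 `O=C(OCc1ccccc1)N1CCN(C(=S)SCc2cn(Cc3ccc(Cl)cc3)nn2)CC1` in a functional assay on PC-3 cells (Homo sapiens) for inhibition, read by MTT assay, with a stated time of 72 h (on this read-out lower numbers stand for stronger inhibition and higher numbers for weaker inhibition), gives > 128000 nM, a limit of the assay.
Compound 2 `COc1ccc(Cn2cc(CSC(=S)N3CCN(C(=O)OCc4ccccc4)CC3)nn2)cc1` in this assay gives > 128000 nM, also a limit.
Compound 3 `O=C(OCc1ccccc1)N1CCN(C(=S)SCc2cn(Cc3ccccc3F)nn2)CC1` in this assay gives 68300 nM.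

For the measured compounds named here, compound 3 is the only compound with a number; the other two values sit at the limit of > 128000 nM in this assay, at which 2 of the 3 values shown sit. Compound 4 `COc1cc(Cn2cc(CSC(=S)N3CCN(C(=O)OCc4ccccc4)CC3)nn2)cc(OC)c1OC` carries 3,4,5-trimethoxyphenyl in place of 2-fluorophenyl on a saturated chain carbon bound to an aromatic nitrogen. Going by the values given here, the steps that bear on this are an at least 1.8-fold lower number from compound 1 to compound 3 (0.27 log units; that floor lies within the scatter) and an at least 1.8-fold lower number from compound 2 to compound 3 (0.27 log units; that floor lies within the scatter); both run toward the 2-fluorophenyl of compound 3, and both floors lie within the scatter. Reversing that direction, back to a phenyl bearing methoxy groups as in compound 2, suggests the number for compound 4 may rise again, possibly to a limit. For compound 4 the expected step is a 1.6-fold higher number from compound 3 to compound 4 (0.21 log units; within the scatter). Compound 4 is estimated at 110000 nM, in the range 40000 nM to 300000 nM.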

Compound 4, half-maximal inhibitory concentration: > 128000 nM
Compound 4: a limit, no number; the forecaster's own chance of this, stated with the estimate: 50%; middle value at least 1.1-fold (0.06 log units) away from the limit.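

At the saturated chain carbon bound to an aromatic nitrogen, 3,4,5-trimethoxyphenyl in place of 2-fluorophenyl gives an at least 1.8-fold higher number from compound 3 to compound 4 (0.27 log units; that floor lies within the scatter) in this assay. Compound 4 gives > 128000 nM, a limit of the assay and not a number. The steps to compound 4 from compound 1 and compound 2 cannot be read, and 2-fluorophenyl remains the only group here with a number: the limit of > 128000 nM in this assay, at which 3 of the 4 values shown sit.

On these data alone, whether the number of compound 3 depends on the fluorine remains open. So does what an amine or a carboxylic acid on this phenyl would give in this assay.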